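This account rests on a few compounds, and the source may have more. Where it says the series, first, only, none or still open, it means among the compounds named here.

Of the compounds shown here, three have been measured. Compound 1 `Cc1c(OCCCCOc2ccc(F)c(C(=O)O)c2)ccc(C(=O)CC(C)(C)C)c1O` gives 94.6% in an assay on HEK293 cells for positive allosteric modulation of metabotropic glutamate receptor 2 (Rattus norvegicus), read by thallium flux, with a stated time of 2.5 min; a higher number here means a larger maximal response, a lower number a smaller maximal response. Compound 2 `Cc1c(OCCCCOc2ccc(C(=O)O)c(Cl)c2)ccc(C(=O)CC2CCCC2)c1O` gives 80.8% in the same assay. Compound 3 `CCC(=O)c1ccc(OCCCCOc2ccc(F)c(C(=O)O)c2)c(C)c1O` gives 66.6%, the lowest of the three numbers shown; compound 2 stands above it by a margin beyond the scatter, and compound 1 stands furthest above it. For the measured compounds named here, the one step recorded between these compounds runs from compound 1 to compound 3: a number 28 percentage points lower from compound 1 to compound 3 (beyond the scatter).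

The unmeasured compound 4 `Cc1c(OCCCCOc2ccc(F)c(C(=O)O)c2)ccc(C(=O)CC2CCCC2)c1O` differs from compound 3 in one place: cyclopentyl in place of methyl on a saturated chain carbon bound to a carbonyl carbon. The step from compound 1 to compound 3 is the one that bears on this change, since it shows how this assay responded when the group on the saturated chain carbon bound to the carbonyl carbon shrank to methyl; the change to compound 4 goes in the opposite direction, and compound 2, which carries cyclopentyl at that position together with other differences, also shows a higher value than compound 3. The expected step is therefore upward, roughly a number 18.4 percentage points higher from compound 3 to compound 4 (beyond the scatter). Compound 4 is expected to give about 85%, within a range of 70% to 100%.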

Compound 4, largest response reached (reported as percent of maximum), in percent of the reference or control that the assay uses: 81%
Compound 4: middle estimate off by 4 percentage points, on the high side; the measured number falls inside the stated range.
By their numbers in this assay, from the lowest: compound 3; then compounds 2 and 4 (each within the scatter of the next); then compound 1.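

In this assay, cyclopentyl in place of methyl on a saturated chain carbon bound to a carbonyl carbon raises the response (a number 14.4 percentage points higher from compound 3 to compound 4 (beyond the scatter)), but cyclopentyl does not reach the level of tert-butyl at that place (a number 13.6 percentage points lower from compound 1 to compound 4 (beyond the scatter)), so these three compounds rank methyl, then cyclopentyl, then tert-butyl. With cyclopentyl held fixed, 3-carboxy-4-fluorophenyl in place of 4-carboxy-3-chlorophenyl on an oxygen on a saturated carbon makes no difference that can be read (a number 0.2 percentage points higher from compound 2 to compound 4 (within the scatter)). Nothing available here accounts for these differences.

From the compounds shown here alone, how a cyclohexyl, a phenyl or a straight butyl chain would compare at this place remains open. So does whether the two carboxyphenyl groups would also stay level with tert-butyl or methyl in place of cyclopentyl.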